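Neopentyl in place of methyl on the shared core

A few compounds are considered here, and "the series" means these few. Any claim that something is new, unique, unknown or untested is made for them only; others in the source may bear on it.

Compound 3 `Cn1cc2c(Cl)nc(N)nc2n1` is the smallest member of the set. In a functional assay on CHO cells for antagonist activity at adenosine receptor A2b (Homo sapiens), read by 33P incorporation, with a stated time of 20 min, in the presence of a further agent that is not named here (on this read-out higher numbers stand for weaker inhibition and lower numbers for stronger inhibition), compound 3 gives > 20000 nM, which is a limit of the assay and not a number. Compound 2 `CC(C)(C)Cn1cc2c(Cl)nc(N)nc2n1` differs from compound 3 by tert-butyl in place of hydrogen on a saturated chain carbon bound to an aromatic nitrogen. In this assay compound 2 gives > 10000 nM, again a limit. The step that the two limits leave unreadable from compound 3 to compound 2 therefore rests only on the limit of > 10000 nM in this assay, at which 1 of the 3 values shown sits, and (the limit of > 20000 nM in this assay, at which 2 of the 3 values shown sit). Compound 1 `Cn1cc2c(Cl)nc(NC(=O)c3ccc(C(F)(F)F)cc3)nc2n1` carries a larger substituent on the shared core; the difference between the two cores is not broken down here. In this assay compound 1 gives > 20000 nM, a limit once more. Compound 4 `CC(C)(C)Cn1cc2c(Cl)nc(NC(=O)c3ccc(C(F)(F)F)cc3)nc2n1` has not yet been measured and differs from compound 1 by tert-butyl in place of hydrogen on a saturated chain carbon bound to an aromatic nitrogen, the same change as from compound 3 to compound 2. The expected step of an at least 1.3-fold lower number from compound 1 to compound 4 (0.12 log units; that floor lies within the scatter) rests on the step that the two limits leave unreadable from compound 3 to compound 2. Compound 4 is estimated at 15000 nM, between 2000 nM and 60000 nM.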

Compound 4, inhibition constant: > 20000 nM
Compound 4: a limit, no number; the forecaster's own chance of this, stated with the estimate: 70%; at least 1.3-fold (0.12 log units) between middle value and limit.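

Compound 1 and compound 4 both stand at limits of this assay, not numbers, so no step can be read between them. The compounds shown leave open whether neopentyl in place of methyl changes the inhibition constant at all, in either pair.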